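Fluoro addition on the fluoroanilide ring of a thiazole series

The source may hold more compounds than are shown below. What is called first, only, known or untested is meant among the compounds shown, and "the series" means these compounds.

Measured compounds:
- compound 1, `CNC(=O)c1ccc(F)c(NCc2cnc(Nc3ccccn3)s2)c1`: > 2500 nM
- compound 2, `O=C(NC1CC1)c1ccc(F)c(NCc2cnc(Nc3ccccn3)s2)c1`: > 2500 nM

In a functional assay on L2987 cells (Homo sapiens) for antiproliferative activity (on this read-out lower numbers stand for stronger inhibition and higher numbers for weaker inhibition), compound 1 gives > 2500 nM, which is a limit of the assay and not a number. For compound 2 the read-out is > 2500 nM, likewise a limit. For the measured compounds named here, the one step among the measured pair, a step that the two limits leave unreadable from compound 1 to compound 2, cannot be sized, because the limit of > 2500 nM in this assay, at which 2 of the 2 values shown sit, holds both values. Compound 1 therefore stands at that limit with no further number beside it.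

Compound 3, `CNC(=O)c1cc(NCc2cnc(Nc3ccccn3)s2)c(F)cc1F`, is not yet measured. It differs from compound 1 by fluoro in place of hydrogen on an aromatic carbon. No measured step bears on this change: the only step shown, cyclopropyl in place of methyl on an amide-type nitrogen, is unreadable and concerns a different position. Since compound 1 sits at the limit, no direction can be read from the data, and a step beyond the scatter is not expected in either direction.

The estimate for compound 3 is 5000 nM with a range of 2500 nM to 20000 nM. This estimate means an expected step that the limit leaves unreadable from compound 1 to compound 3, most likely another limit.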

Compound 3, half-maximal inhibitory concentration: > 2500 nM
Compound 3 was reported as a limit; the forecaster's own chance of this, stated with the estimate: 80%; the middle value lies beyond the limit too.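

In this assay compound 3 gives > 2500 nM which is a limit of the assay and not a number. No step from compound 1 to compound 3 can be read, since both stand at the same limit: the limit of > 2500 nM in this assay, at which 3 of the 3 values shown sit.

The compounds shown leave open how far each of the three lies beyond that limit, and whether either change alters the read-out at all.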